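The source may hold more compounds than are shown below. What is called first, only, known or untested is meant among the compounds shown, and "the series" means these compounds.

Compounds measured so far:
- compound 1 `CCc1nn2c(C)cc(C)nc2c1Cc1ccc(/C=C/CN2CCN(C(C)C)CC2)cc1`: 43 nM
- compound 2 `CCc1nn2c(C)cc(C)nc2c1Cc1ccc(/C=C/CN2CCNCC2=O)cc1`: 73 nM
- compound 3 `CCc1nn2c(C)cc(C)nc2c1Cc1ccc(-c2nnc(N3CCNCC3)o2)cc1`: 368 nM

All three were tested in a functional assay on HeLa cells for antagonist activity at G-prodeshotein coupled receptor 4 (Homo sapiens), read by HTRF and cAMP accumulation, with a stated time of 15 min; on this read-out higher numbers stand for weaker inhibition and lower numbers for stronger inhibition. Among the compounds with values here, compound 2 gives the second highest of the three numbers: compound 1 lies close to it, and the one step known between them, a 1.7-fold higher number from compound 1 to compound 2 (0.23 log units; within the scatter), falls within the usual scatter. Compound 3, by contrast, gives a clearly higher number than compound 2, but those two differ in more than one place, so only their two values can be compared.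

The unmeasured compound 4 `CCc1nn2c(C)cc(C)nc2c1Cc1ccc(CCCC2(O)CCNCC2)cc1` keeps the shared core of compound 2 and changes the chain attached to the aromatic ring: 3-(4-hydroxypiperidin-4-yl)propyl in place of 3-(2-oxopiperazin-1-yl)prop-1-en-1-yl on an aromatic carbon. Within the data shown here, the only measured step that touches this region, from compound 1 to compound 2, swapped one ring at the end of the chain for another and moved the number very little. Among the measured compounds shown here, the change to compound 4 is larger, removing both double bonds and replacing the ring, and no measured pair covers that kind of change. The expectation is therefore a modest shift in this assay, possibly a somewhat higher number, with wide uncertainty. Compound 4 is estimated at 120 nM, in the range 40 nM to 400 nM, which means an expected step of a 1.6-fold higher number from compound 2 to compound 4 (0.22 log units; within the scatter).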

Compound 4, half-maximal inhibitory concentration: 50 nM
Beside the measured number, compound 4's estimate is 2.4-fold (0.38 log units) above it; measured number inside the range.
By their numbers in this assay, from the lowest: compounds 1, 4 and 2 (each within the scatter of the next); then compound 3.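

In this assay the result shows that the whole chain on this aromatic carbon, para to a large group, can be rebuilt and still give a 1.5-fold lower number from compound 2 to compound 4 (0.16 log units; within the scatter). Within the data shown here, until now, the only readable step had replaced one ring at the end of an unsaturated chain with another; here 3-(4-hydroxypiperidin-4-yl)propyl replaces 3-(2-oxopiperazin-1-yl)prop-1-en-1-yl, so the double bonds outside aromatic rings are gone and the ring holds one fewer hetero atom, yet the two compounds cannot be told apart. For this pair, then, a fully saturated chain serves as well as the unsaturated one, and no available evidence bears on why.

Still open, going by these compounds, is how each part of the change counts alone, which a propyl chain carrying 2-oxopiperazin-1-yl or a prop-1-en-1-yl chain carrying 4-hydroxypiperidin-4-yl could separate. The compounds shown also leave open how a longer chain such as butyl would read here, or an amine or a carboxylic acid in place of the hydroxyl group on the piperidine ring.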